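The source may hold more compounds than are shown below. What is called first, only, known or untested is meant among the compounds shown, and "the series" means these compounds.

Working notes on the sulfonyl pyroglutamyl hydrazide series, read in a functional assay on the whole organism with Mus musculus as the target, at a dose of 50 mg/kg by the intraperitoneal route; on this read-out higher numbers stand for more inhibition at the one dose given (going by the name of the read-out) and lower numbers for less inhibition.

Three compounds have numbers. Compound 1 `Cc1ccc(S(=O)(=O)N2C(=O)CCC2C(=O)NN)cc1` gives 52.8% in this assay. Compound 2 `NNC(=O)C1CCC(=O)N1S(=O)(=O)c1ccc(Cl)cc1` gives 61.1% in this assay. Compound 3 `O=C(NNc1ccccc1)C1CCC(=O)N1S(=O)(=O)c1ccc(Cl)cc1` gives 71.4% in this assay. Compound 2 stands second highest of the three: its nearest neighbour is compound 1, with the step of a number 8.3 percentage points higher from compound 1 to compound 2 (within the scatter), and its furthest is compound 3, with the step of a number 10.3 percentage points higher from compound 2 to compound 3 (beyond the scatter).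

Compound 4 `NNC(=O)C1CCC(=O)N1S(=O)(=O)c1ccc(Cl)c(Cl)c1` is not yet measured. It differs from compound 2 in one place: chloro in place of hydrogen on an aromatic carbon, the new chloro sitting ortho to the chloro group already present and meta to the large group.

Among the compounds with values here, of the measured steps, only the step from compound 1 to compound 2 touches the same aromatic ring, and it was within the scatter; the step from compound 2 to compound 3 changes the amine nitrogen instead and does not bear directly on a second aromatic chloro. The expected step in this assay is therefore small, a number 1.9 percentage points higher from compound 2 to compound 4 (within the scatter), with no clear direction beyond the scatter. Compound 4 is estimated at 63%, in the range 50% to 76%.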

Compound 4, a percentage reported as inhibition, in the whole organism at one dose (the size of the read-out at that dose, not a potency): 58.3%
Estimate against measurement, compound 4: 4.7 percentage points above, and the stated range covers the measured number.
By their numbers in this assay, from the lowest: compounds 1, 4 and 2 (each within the scatter of the next); then compound 3.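

In this assay, adding a chloro on the aromatic carbon ortho to the chloro group already present and meta to the large group gives a number 2.8 percentage points lower from compound 2 to compound 4 (within the scatter), so compound 2 and compound 4 cannot be told apart. Within the data shown here, this is the first reading at this place on the ring, where the earlier step on the same ring exchanged one group for another at a carbon already substituted; here a hydrogen gives way to a chloro and the read-out shows no change beyond the scatter. Nothing available explains this outcome for the second chloro.

Going by these compounds, whether a methoxy group, an amine or a carboxylic acid at this same place would give a step beyond the scatter stays open. Also open, on these data alone, is whether this second chloro would read the same on compound 3, with its phenyl on the amine nitrogen.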